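Cyclopropyl Amide Replacing Hydrazide on a Pyridine Core

The source may hold more compounds than are shown below. What is called first, only, known or untested is meant among the compounds shown, and "the series" means these compounds.

Compound 1 `NNC(=O)CCc1ccncc1-c1ccc2ccccc2c1` is tested in a functional assay on MCF7 cells (Homo sapiens) for inhibition, read by sulforhodamine B assay, with a stated time of 72 h; on this read-out higher numbers stand for weaker inhibition of growth and lower numbers for stronger inhibition of growth. In this assay compound 1 gives only a limit, > 10000 nM, so its growth inhibition is weak and its exact value unknown (the limit of > 10000 nM in this assay, at which 1 of the 2 values shown sits). A related compound 2 `CCOC(=O)/C=C/c1ccncc1-c1ccc2c(ccn2C)c1` gives in this assay 8670 nM. Compound 3 `O=C(/C=C/c1ccncc1-c1ccc2ccccc2c1)NC1CC1` differs from compound 1 by 2-(cyclopropylcarbamoyl)ethenyl in place of 2-(aminocarbamoyl)ethyl on an aromatic carbon. Within the data shown here, no measured pair shows this change, so its size is open. Compound 3 is expected to show a gain in growth inhibition, an at least 1.6-fold lower number from compound 1 to compound 3 (0.22 log units; that floor lies within the scatter), that may not exceed the usual scatter. Compound 3 is estimated at 6000 nM, between 1500 nM and 20000 nM.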

Compound 3, concentration for 50% growth inhibition: 6840 nM
Estimate against measurement, compound 3: 1.1-fold (0.06 log units) below, within the range that was stated.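

In this assay, 2-(cyclopropylcarbamoyl)ethenyl in place of 2-(aminocarbamoyl)ethyl at this position gives an at least 1.4-fold lower number from compound 1 to compound 3 (0.16 log units; that floor lies within the scatter), so this group yields a real number where the earlier chain gave only a limit. The true size of the step remains unknown, because one end of it is a limit: the limit of > 10000 nM in this assay, at which 1 of the 3 values shown sits.

The change alters the chain's double bond and the group on the amide nitrogen together, and the compounds shown do not separate the two. From the compounds shown here alone, how a saturated 2-(cyclopropylcarbamoyl)ethyl group or a carboxylic acid would behave here stays open.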